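Replacing a two-ring group on a carbonyl carbon

This account rests on a few compounds, and the source may have more. Where it says the series, first, only, none or still open, it means among the compounds named here.

In an ADME assay on Caco-2 cells (Homo sapiens) for permeability, in the apical to basolateral direction, at pH 7.4 (a higher number here means that the compound crosses the layer faster, a lower number that the compound crosses the layer more slowly), compound 2 (`O=C(N[C@H]1CN(S(=O)(=O)c2ccccc2)C[C@@H]1C(=O)N1C[C@H]2CCNC[C@H]21)c1cc(-c2ccccc2Cl)on1`) gives 0.53 10^-6 cm/s and stands level with compound 1 (`O=C(N[C@H]1CN(S(=O)(=O)c2ccccc2)C[C@@H]1C(=O)N[C@H]1CCCNC1)c1cc(-c2ccccc2Cl)on1`), which gives 0.31 10^-6 cm/s in the same measurement. Compound 3 (`O=C(N[C@H]1CN(S(=O)(=O)c2ccccc2)C[C@@H]1C(=O)NC[C@@H]1CCCN1)c1cc(-c2ccccc2Cl)on1`) is reached from compound 2 by a group of 7 heavy atoms (5 carbon, 2 nitrogen; one five-membered non-aromatic ring with 1 hetero atom) in place of a group of 8 heavy atoms (6 carbon, 2 nitrogen; one four-membered non-aromatic ring with 1 hetero atom, one six-membered non-aromatic ring with 1 hetero atom), on a carbonyl carbon and so carries ((pyrrolidin-2-yl)methyl)amino on a carbonyl carbon. Within the data shown here, the one measured step that bears on this change, made on that same carbonyl carbon, is a 1.7-fold higher number from compound 1 to compound 2 (0.23 log units; within the scatter) and stays within the scatter. No step beyond the scatter is therefore expected in this assay for the new group, although a single step is thin evidence. The expected change is a 1.3-fold lower number from compound 2 to compound 3 (0.12 log units; within the scatter) and this direction is held only weakly. Compound 3 is expected at 0.4 10^-6 cm/s with an estimated range of 0.13 10^-6 cm/s to 1.2 10^-6 cm/s for the coming measurement.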

Compound 3, apparent permeability: 0.44 10^-6 cm/s
Compound 3: the middle estimate sits 1.1-fold (0.04 log units) below what was measured, within the range that was stated.
By their numbers in this assay, from the lowest: compounds 1, 3 and 2 (each within the scatter of the next).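

In this assay, a third group on this carbonyl carbon again gives no step beyond the scatter (a 1.2-fold lower number from compound 2 to compound 3 (0.08 log units; within the scatter)). This holds with one five-membered non-aromatic ring in place of a four-membered and a six-membered one, and with 2 hydrogen-bond donors in place of 1. The exchange of piperidin-3-yl for (pyrrolidin-2-yl)methyl on an amide-type nitrogen also stays within the scatter (a 1.4-fold higher number from compound 1 to compound 3 (0.15 log units; within the scatter)), and nothing available accounts for these groups standing level.

The compounds shown leave open whether a group without a ring, such as an open-chain amine, or a carboxylic acid on this carbonyl carbon would give a step beyond the scatter. They also leave open whether changes elsewhere on the shared core would do so.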